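This account rests on a few compounds, and the source may have more. Where it says the series, first, only, none or still open, it means among the compounds named here.

Compound 1 `CC(C)Oc1cc(=O)oc2cc(OCc3cccc(Cl)c3)ccc12` gives 24500 nM in an assay on isolated protein (strain Sprague-Dawley) for inhibition of Amine oxidase [flavin-containing] B (Rattus norvegicus), read by spectrophotometry, with a stated time of 5 min; on this read-out lower numbers stand for stronger inhibition and higher numbers for weaker inhibition. Compound 2 `CCOC(=O)COc1cc(=O)oc2cc(OCc3cccc(Cl)c3)ccc12` gives 1820 nM in this assay. Compound 3 `O=C(COc1cc(=O)oc2cc(OCc3cccc(Cl)c3)ccc12)N1CCCCC1` gives 38900 nM in this assay.

Compound 3 has the highest number of the three; one step is a 1.6-fold higher number from compound 1 to compound 3 (0.20 log units; within the scatter), the other is a 21-fold higher number from compound 2 to compound 3 (1.33 log units; beyond the scatter). Compound 4 `CNc1cc(=O)oc2cc(OCc3cccc(Cl)c3)ccc12` differs from compound 3 by methylamino in place of ((piperidin-1-yl)carbonyl)methoxy on an aromatic carbon. Within the data shown here, no measured step swaps the whole side chain for a small group, so none bears on this change directly. The two steps that change this position, a 13-fold lower number from compound 1 to compound 2 (1.13 log units; beyond the scatter) and a 21-fold higher number from compound 2 to compound 3 (1.33 log units; beyond the scatter), were both large, so a sizeable move in either direction is possible. The expected step is a 1.9-fold lower number from compound 3 to compound 4 (0.29 log units; within the scatter), with wide uncertainty. Compound 4 is estimated at 20000 nM, between 4000 nM and 100000 nM.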

Compound 4, half-maximal inhibitory concentration: 8.71 nM
The estimate for compound 4 lay 2300-fold (3.36 log units) above the measured number; the measured number lies below the stated range.
By their numbers in this assay, from the lowest: compound 4; then compound 2; then compounds 1 and 3 (each within the scatter of the next).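

In this assay, methylamino on this aromatic carbon gives a 4500-fold lower number from compound 3 to compound 4 (3.65 log units; beyond the scatter) and a 210-fold lower number from compound 2 to compound 4 (2.32 log units; beyond the scatter) and a 2800-fold lower number from compound 1 to compound 4 (3.45 log units; beyond the scatter) as it replaces each oxygen-linked side chain. Each of these steps is larger than any step among the earlier compounds, so this position can shift the number much further than changes within those side chains had shown. Nothing available explains the size of these steps. The change swaps the linking atom and shortens the group together, so the two effects stay unseparated. Methoxy, a plain amino group and dimethylamino at this position would help tell them apart.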